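From Methyl to Phenyl on a Tetrazole Nitrogen

The source may report more compounds than this note shows. Statements on the series, on what has been measured and on what is new or still open speak of the compounds shown alone.

Compounds measured so far:
- compound 1, `COC(=O)c1ccc(OCc2nc(C)c(C)nc2C)c(OC)c1`: 16%
- compound 2, `Cc1nc(C)c(COc2ccc3ccc(=O)oc3c2)nc1C`: 46.6%
- compound 3, `Cc1nc(C)c(CSc2nnnn2C)nc1C`: -117%

All three compounds share a common core and were tested in a functional assay on ECV-304 cells (Homo sapiens), read by MTT assay, with stated times of 24 h and 12 h, tested at 100 uM; on this read-out higher numbers stand for a stronger effect at the one concentration tested and lower numbers for a weaker effect. Compound 1 gives 16%, compound 2 gives 46.6%, and compound 3 gives -117%. Compound 3 therefore stands lowest of the three; its nearest neighbour is compound 1, whose number is higher by an amount beyond the usual scatter, and compound 2 stands even further above it. Among the compounds with values here, no two measured compounds differ in only one place, so no single step can be read from these numbers.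

Compound 4, `Cc1nc(C)c(CSc2nnnn2-c2ccccc2)nc1C`, differs from compound 3 in one place: phenyl in place of methyl on an aromatic nitrogen. Because compound 3 sits at -117%, far beneath both other compounds, and no comparable change has been measured here, the direction of this step is not known from the data. The expected step of a number 77 percentage points higher from compound 3 to compound 4 (beyond the scatter) in this assay is upward, of a size beyond the scatter, but with wide uncertainty. Compound 4 is estimated to give -40%, with a range from -130% to 40%.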

Compound 4, a percentage reported as activity, at one concentration (the size of the read-out at that concentration, not a potency): -136%
Compound 4: middle estimate off by 96 percentage points, on the high side; the measured number lies below the stated range.
By their numbers in this assay, from the lowest: compound 4; then compound 3; then compound 1; then compound 2.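

Within the data shown here, putting phenyl in place of methyl on an aromatic nitrogen of the five-membered aromatic ring with 4 nitrogen gives, in this assay, a number 19 percentage points lower from compound 3 to compound 4 (beyond the scatter) and this is the first change in one place that can be read from these compounds. The number is negative on both sides of the step, so going from 1 heavy atom to 6 heavy atoms at this nitrogen, and adding a six-membered aromatic ring of carbon only, does not bring the read-out up but moves it a modest way further down. Nothing measured here bears on why the number moved in this direction.

With only methyl and phenyl shown on this nitrogen, two points cannot tell whether the number follows the size of the group, so an ethyl chain, or a phenyl ring carrying an amine or a carboxylic acid, could fall anywhere relative to them. From the compounds shown here alone, it also stays open whether the same swap would move the number the same way if the rest of the structure were different.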